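Cyclobutyl prostanoid analogues: notes on the path to compound 4

A few compounds are considered here, and "the series" means these few. Any claim that something is new, unique, unknown or untested is made for them only; others in the source may bear on it.

Measured compounds:
compound 1, `CCCCC1([C@H](O)/C=C/C2CCC(=O)[C@@H]2CCCCCCCCC(=O)OCC)CCC1`: 4.38 mg/kg
compound 2, `CCCC1([C@@H](O)/C=C/C2[C@H](O)CC(=O)[C@@H]2C/C=C\CCCC(=O)O)CCC1`: 0.265 mg/kg
compound 3, `CCCCC1([C@H](O)/C=C/C2[C@H](O)CC(=O)[C@@H]2CCCCCCC(=O)O)CCC1`: 0.00126 mg/kg

All three compounds were tested in a functional assay on the whole organism (strain Hartley) for inhibition, with Cavia porcellus as the target, with stated times of 15 min and 2 min; a higher number here means that more compound is needed for the effect, a lower number that less compound is needed. Compound 1 gives 4.38 mg/kg, the highest of the three numbers. Its nearest neighbour is compound 2, whose number is lower by a gap beyond the scatter; compound 3 lies furthest away, with a number lower by a margin far beyond the scatter. Within the data shown here, no two of the measured compounds differ in only one place, so no single step between measured compounds can be read off directly.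

Compound 4, `CCCCC1([C@H](O)/C=C/C2CCC(=O)[C@@H]2CCCCSCC(=O)O)CCC1`, has not yet been measured in this assay. It differs from compound 1 by (carboxymethyl)sulfanyl in place of 4-(ethoxycarbonyl)butyl on a saturated chain carbon, four bonds along the chain from a saturated ring carbon. Compounds 2 and 3 both carry a chain ending with a hydrogen-bond donor, as the entering group of compound 4 does, but both also carry a hydroxyl on the core that compound 1 and compound 4 lack, so their values can only loosely guide the expectation here.

The step from compound 1 to compound 4 is expected to lower the number, beyond the scatter, at a 5.5-fold lower number from compound 1 to compound 4 (0.74 log units; beyond the scatter). Compound 4 is therefore estimated at 0.8 mg/kg, with a range from 0.15 mg/kg to 4 mg/kg.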

Compound 4, dose for half-maximal effect: 0.171 mg/kg
Beside the measured number, compound 4's estimate is 4.7-fold (0.67 log units) above it; the range from low to high includes it.
By their numbers in this assay, from the lowest: compound 3; then compounds 4 and 2 (each within the scatter of the next); then compound 1.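

In this assay, among these compounds, the exchange of 4-(ethoxycarbonyl)butyl for (carboxymethyl)sulfanyl on a saturated chain carbon, four bonds along the chain from a saturated ring carbon, gives a 26-fold lower number from compound 1 to compound 4 (1.41 log units; beyond the scatter) and so provides the first single-place comparison in this set. Among the compounds shown here, it shows that this position alone can produce a large change in the number, with no hydroxyl on the core in either compound, whereas the earlier compounds differed in several places and could not isolate this effect. No available measurement accounts for the size of this step.

For the compounds shown here, the single change shortens the chain, adds sulfur and replaces an ethyl ester end with a free acid end, so the share of each in the step remains unresolved. The compounds shown also leave open how an ether oxygen in place of the sulfur, or a primary amide at the chain end, would read at this position.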